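The source may report more compounds than this note shows. Statements on the series, on what has been measured and on what is new or still open speak of the compounds shown alone.

Compound 1 `CONc1nc(C#CCCCC#N)nc2c1ncn2[C@@H]1O[C@H](CO)[C@@H](O)[C@H]1O` gives the lowest number of the three measured compounds in an assay on CHO cells for displacement of a labelled ligand from adenosine receptor A1 (Homo sapiens) (on this read-out higher numbers stand for weaker inhibition and lower numbers for stronger inhibition), with 282 nM. Compound 2 `CONc1nc(C#Cc2ccncc2)nc2c1ncn2[C@@H]1O[C@H](CO)[C@@H](O)[C@H]1O` gives 1190 nM, and compound 3 `CONc1nc(C#Cc2cccc(C(F)(F)F)c2)nc2c1ncn2[C@@H]1O[C@H](CO)[C@@H](O)[C@H]1O` gives 2450 nM. Both steps away from compound 1 weakened inhibition: a 4.2-fold higher number from compound 1 to compound 2 (0.63 log units; beyond the scatter) and an 8.7-fold higher number from compound 1 to compound 3 (0.94 log units; beyond the scatter). Compound 4 `C#Cc1nc(NOC)c2ncn([C@@H]3O[C@H](CO)[C@@H](O)[C@H]3O)c2n1` differs from compound 1 by hydrogen in place of 3-cyanopropyl on a triple-bonded carbon. Going by the values given here, no measured step removes the 3-cyanopropyl group without putting a ring in its place, so those two steps bear on the change only loosely; they show that every alteration at this position so far has raised the number. A modest weakening is therefore expected, a 2.3-fold higher number from compound 1 to compound 4 (0.36 log units; beyond the scatter), with wide uncertainty. Compound 4 is estimated at 650 nM, expected to fall between 200 nM and 2100 nM.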

Compound 4, inhibition constant: 25 nM
Estimate against measurement, compound 4: 26-fold (1.41 log units) above; measured number outside the range, below it.
By their numbers in this assay, from the lowest: compound 4; then compound 1; then compound 2; then compound 3.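

Putting hydrogen on the triple-bonded carbon strengthens inhibition in this assay by a large margin over 3-cyanopropyl (an 11-fold lower number from compound 1 to compound 4 (1.05 log units; beyond the scatter)), pyridin-4-yl (a 48-fold lower number from compound 2 to compound 4 (1.68 log units; beyond the scatter)) and 3-(trifluoromethyl)phenyl (a 98-fold lower number from compound 3 to compound 4 (1.99 log units; beyond the scatter)). The earlier compounds shown here only compared substituents with one another, whereas compound 4 shows that all three, chain and rings alike, give weaker inhibition than no substituent at all. No available evidence explains this gain.

From the compounds shown here alone, whether a single methyl group or a short chain ending in an amine would keep the strength of compound 4 remains open.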